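Aryl ether change on a level set of values

The compounds below may be only part of what the source reports. "The series", "measured", "known", "first", "only" and "open" are said of these compounds alone.

In a functional assay on CRL2813 cells (Homo sapiens) for antiproliferative activity, read by sulforhodamine B assay, with a stated time of 3 days, in the presence of a further agent that is not named here (a higher number here means a weaker inhibitor, a lower number a stronger inhibitor), compound 1 `O=C(Nc1cccc(C(F)(F)F)c1)N[C@H]1CC[C@H](Oc2cccc(C(F)(F)F)c2)CC1` gives 4900 nM and compound 2 `O=C(Nc1cccc(C(F)(F)F)c1)N[C@H]1CC[C@H](Oc2ccc(C(F)(F)F)cc2)CC1` gives 5000 nM while compound 3 `O=C(Nc1cccc(C(F)(F)F)c1)N[C@H]1CC[C@H](Oc2ccc(OC(F)(F)F)cc2)CC1` gives 4900 nM so compound 2 stands level with both, with no order among the three. The change to compound 4 `O=C(Nc1cccc(C(F)(F)F)c1)N[C@H]1CC[C@H](Oc2ccccc2F)CC1` is 2-fluorophenyl in place of 4-(trifluoromethyl)phenyl on an oxygen on a saturated carbon and amounts to 2-fluorophenyl in place of 4-(trifluoromethyl)phenyl on an oxygen on a saturated carbon. Going by the values given here, two measured steps bear on it, a 1.0-fold higher number from compound 1 to compound 2 (0.01 log units; within the scatter) and a 1.0-fold lower number from compound 2 to compound 3 (0.01 log units; within the scatter) and both lie within the scatter. Neither step tests 2-fluorophenyl, so the support is indirect. In this assay the expected step is a 1.1-fold higher number from compound 2 to compound 4 (0.04 log units; within the scatter) and no move beyond the scatter is expected. For compound 4 the estimated value is 5500 nM (expected range 2500 nM to 12000 nM).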

Compound 4, half-maximal inhibitory concentration: 21900 nM
The estimate for compound 4 lay 4.0-fold (0.60 log units) below the measured number; the measured number lies above the stated range.
By their numbers in this assay, from the lowest: compounds 1, 3 and 2 (each within the scatter of the next); then compound 4.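

In this assay the aryl group on the ether oxygen proves not to be indifferent: the record shows a 4.4-fold higher number from compound 2 to compound 4 (0.64 log units; beyond the scatter) and a 4.5-fold higher number from compound 1 to compound 4 (0.65 log units; beyond the scatter) while the three earlier aryl groups gave no separation. Of the groups shown, only 2-fluorophenyl moves the number, and it moves towards a weaker inhibitor. No measurement here accounts for the shift.

Compound 4 replaces both the substituent and its place on the ring, so the two changes cannot be separated. Going by these compounds, whether a plain phenyl or a methoxyphenyl stays level with compound 2 or follows compound 4 remains open.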